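A few compounds are considered here, and "the series" means these few. Any claim that something is new, unique, unknown or untested is made for them only; others in the source may bear on it.

Working notes on the series in an assay on HeLa cells for inhibition of Indoleamine 2,3-dioxygenase 1 (Homo sapiens), read by spectrophotometry, with a stated time of 24 h; a lower number here means that less compound is needed, a higher number that more compound is needed for the effect.

Three compounds share the same core and differ only in the group on a nitrogen on an aromatic ring. Compound 1 `[O-][S+]1CC(Nc2nonc2/C(=N/O)Nc2ccc(F)c(Br)c2)C1` gives 79 nM. Compound 2 `O=S1(=O)CC(Nc2nonc2/C(=N/O)Nc2ccc(F)c(Br)c2)C1` gives 59 nM. Compound 3 `CCNS(=O)(=O)CCNc1nonc1/C(=N/O)Nc1ccc(F)c(Br)c1` gives 41 nM, the lowest of the three numbers, though its nearest neighbour compound 2 lies a 1.4-fold lower number from compound 2 to compound 3 (0.16 log units; within the scatter) and compound 1 lies a 1.9-fold lower number from compound 1 to compound 3 (0.28 log units; within the scatter), both within the scatter, so no order among the three can be read. The step of a 1.3-fold lower number from compound 1 to compound 2 (0.13 log units; within the scatter) is also within the scatter.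

Compound 4 `NNS(=O)(=O)CCNc1nonc1/C(=N/O)Nc1ccc(F)c(Br)c1` is not yet measured. It differs from compound 3 by amino in place of ethyl on a sulfonamide nitrogen.

None of the three measured steps touches the sulfonamide nitrogen; all sit on the nitrogen on the aromatic ring, where exchanges of rings for an open chain moved the number by less than the scatter. Going by the values given here, the series gives no direct step for amino in place of ethyl on a sulfonamide nitrogen. Among the compounds with values here, the only guidance is that changes in this region of compound 1, compound 2 and compound 3 have stayed within the scatter, so for compound 4 a step of about a 1.2-fold higher number from compound 3 to compound 4 (0.09 log units; within the scatter) is expected, no direction beyond the scatter. The number expected for compound 4 in this assay is 50 nM, with a range from 20 nM to 130 nM.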

Compound 4, half-maximal effective concentration: > 800 nM
Compound 4: only a limit was reported; the forecaster's own chance of this, stated with the estimate: 3%; at least 16-fold (1.20 log units) between middle value and limit.
By their numbers in this assay, from the lowest: compounds 3, 2 and 1 (each within the scatter of the next). At a limit, above all of these: compound 4.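

In this assay, compound 4 stands at a limit and not at a number: the limit of > 800 nM in this assay, at which 1 of the 4 values shown sits.

Going by these compounds alone, the sulfonamide nitrogen is the first place where a single change carries the number beyond the scatter: amino in place of ethyl gives an at least 19-fold higher number from compound 3 to compound 4 (1.29 log units; beyond the scatter). The earlier exchanges on the nitrogen on the aromatic ring, from rings to an open chain, all stayed within the scatter, whereas the two compounds with a four-membered ring now also sit well apart from compound 4, with an at least 13-fold higher number from compound 2 to compound 4 (1.13 log units; beyond the scatter) and an at least 10-fold higher number from compound 1 to compound 4 (1.00 log units; beyond the scatter). Compound 3 and compound 4 both carry the open chain and differ only in ethyl and amino, so within these compounds the open chain alone does not go with the large step.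

Going by these compounds, how far the true number of compound 4 lies past its limit stays open, and with it the full size of all three steps. Also open, on these data alone, is how the number responds to other groups on the sulfonamide nitrogen, such as methyl, a longer chain such as propyl, or a hydroxyl, which would show whether the step follows the loss of ethyl or the arrival of amino.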